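Methyl removal on the pyrazin-2-yl amide: estimate for compound 4

A few compounds are considered here, and "the series" means these few. Any claim that something is new, unique, unknown or untested is made for them only; others in the source may bear on it.

Measured so far:
compound 1 `Cc1cnc(C(=O)Nc2ccc(Br)c3cccnc23)cn1`: 2200 nM
compound 2 `Cc1cnc(C(=O)Nc2cc(F)cc3cccnc23)cn1`: 310 nM
compound 3 `O=C(Nc1ccc(Br)c2cccnc12)c1cnccn1`: 750 nM

All three were run in a functional assay on MIA PaCa-2 cells (Homo sapiens) for inhibition, read by MTT assay, with a stated time of 72 h; a lower number here means a stronger inhibitor, a higher number a weaker inhibitor. Compound 2 stands lowest of the three, compound 3 nearest to it and compound 1 furthest. The change hydrogen in place of methyl on an aromatic carbon gave a 2.9-fold lower number from compound 1 to compound 3 (0.47 log units; beyond the scatter). Compound 4 `O=C(Nc1cc(F)cc2cccnc12)c1cnccn1` is not yet measured; it differs from compound 2 by hydrogen in place of methyl on an aromatic carbon, the same change at the same place. The difference between the cores of compound 1 and compound 2 is not broken down here. A single prior step is a thin basis, so a somewhat smaller step is expected from compound 2 to compound 4, a 2.4-fold lower number from compound 2 to compound 4 (0.38 log units; beyond the scatter), resting on the earlier 2.9-fold lower number from compound 1 to compound 3 (0.47 log units; beyond the scatter). Compound 4 is expected to give about 130 nM in this assay, with a range of 50 nM to 400 nM.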

Compound 4, half-maximal inhibitory concentration: 130 nM
Estimate against measurement, compound 4: no gap at the digits printed, and the stated range covers the measured number.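

Removing the methyl, 5-methylpyrazin-2-yl to pyrazin-2-yl, gives in this assay a 2.4-fold lower number from compound 2 to compound 4 (0.38 log units; beyond the scatter). Set beside the earlier step on the other core, the two cannot be told apart: the same change on two cores in this assay, a 2.9-fold lower number (0.47 log units; beyond the scatter) from compound 1 to compound 3 and a 2.4-fold lower number (0.38 log units; beyond the scatter) from compound 2 to compound 4, 1.2-fold (0.09 log units) apart, within the scatter of two such steps. The change therefore carries across these two cores in this assay with its direction and approximate size intact, but two cores are a thin sample: nothing here shows it holding on a third core, and nothing gives a reason for the lower number.

As far as these compounds go, whether an amine, a methoxy group or a longer chain on that aromatic carbon would lower or raise the number remains open. Also open, from the compounds shown here alone, is whether the step holds in any read-out other than this assay.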